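Swapping 4-methoxyphenoxy for isobutyl on the shared core

The source may report more compounds than this note shows. Statements on the series, on what has been measured and on what is new or still open speak of the compounds shown alone.

Measured in an ADME assay on HepG2 cells (Homo sapiens) for cytotoxicity, read by luminescence, CellTiter-Glo and ATP content, with a stated time of 72 h; on this read-out lower numbers stand for an effect already at smaller amounts and higher numbers for an effect only at larger amounts of compound:
- compound 1 `COc1cccc(CNCCCNc2ccnc3cc(C4CCCCC4)ccc23)c1O`: 1080 nM
- compound 2 `CC(C)Cc1ccc2c(NCCCNCc3ccco3)ccnc2c1`: 16000 nM
- compound 3 `COc1ccc(Oc2ccc3c(NCCCNCc4cccc(OC)c4O)ccnc3c2)cc1`: 5500 nM

Among these three, compound 3 stands in the middle at 5500 nM, with compound 2 higher at 16000 nM and compound 1 lower at 1080 nM.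

The next compound to be tested is compound 4 `COc1cccc(CNCCCNc2ccnc3cc(CC(C)C)ccc23)c1O`, which carries isobutyl in place of 4-methoxyphenoxy on an aromatic carbon. For the measured compounds named here, one measured step bears on this change directly, at the same place on the core. Putting 4-methoxyphenoxy in place of cyclohexyl gave a 5.1-fold higher number from compound 1 to compound 3 (0.71 log units; beyond the scatter), a modest move. Going by the values given here, compound 4 removes the same group, so a move back toward lower numbers is the likely direction, though no measured pair sets isobutyl against either group with the rest of the structure held constant. Compound 2 also carries isobutyl but differs elsewhere, and its value of 16000 nM argues against expecting a return all the way to compound 1.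

A smaller move than the measured one is therefore expected, and it may not clear the scatter. The expected change is a 1.8-fold lower number from compound 3 to compound 4 (0.26 log units; within the scatter). For compound 4 the estimated value is 3000 nM, with an expected range from 1200 nM to 8000 nM.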

Compound 4, half-maximal effective concentration: 2920 nM
Estimate against measurement, compound 4: 1.0-fold (0.01 log units) above; low and high end bracket the measured number.
By their numbers in this assay, from the lowest: compound 1; then compounds 4 and 3 (each within the scatter of the next); then compound 2.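

In this assay, the change at this aromatic carbon gives a 1.9-fold lower number from compound 3 to compound 4 (0.27 log units; within the scatter) and so does not separate isobutyl from 4-methoxyphenoxy, even though a group with no ring replaces one carrying a six-membered aromatic ring. Cyclohexyl at the same place does stand apart from isobutyl, with a 2.7-fold higher number from compound 1 to compound 4 (0.43 log units; beyond the scatter) beside the earlier 5.1-fold higher number from compound 1 to compound 3 (0.71 log units; beyond the scatter) for 4-methoxyphenoxy, so among these three compounds with the same side chain, only compound 1 separates from the others. With isobutyl held constant, 2-hydroxy-3-methoxyphenyl in place of furan-2-yl on a saturated chain carbon bound to an amine nitrogen gives a 5.5-fold lower number from compound 2 to compound 4 (0.74 log units; beyond the scatter) and shows that this other end of the molecule also moves the number beyond the scatter.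

No evidence at hand explains any of these steps. On these data alone, it remains open whether an amine, a carboxylic acid or a longer chain on this aromatic carbon would stay with isobutyl and 4-methoxyphenoxy or move toward cyclohexyl, and whether the furan-2-yl change would give a similar step with cyclohexyl on the shared core.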